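The source may hold more compounds than are shown below. What is called first, only, known or untested is meant among the compounds shown, and "the series" means these compounds.

Measured in a physicochemical assay for inhibition, read by spectrophotometry, with a stated time of 24 h, tested at 2.5 mM; a lower number here means less inhibition, a higher number more inhibition at the concentration tested (going by the name of the read-out):
compound 1 `O=C(CCN1CCN(c2ccnc3cc(Cl)ccc23)CC1)N/N=C/c1ccccc1Cl`: 87.3%
compound 2 `O=C(CCN1CCN(c2ccnc3cc(Cl)ccc23)CC1)N/N=C/c1ccccc1O`: 83.2%

On the numbers shown compound 2 and compound 1 cannot be told apart, since a number 4.1 percentage points lower from compound 1 to compound 2 (within the scatter) lies within the scatter of this assay. Compound 3 `CN(C)c1ccc(/C=N/NC(=O)CCN2CCN(c3ccnc4cc(Cl)ccc34)CC2)cc1` has not been measured. It differs from compound 2 by 4-(dimethylamino)phenyl in place of 2-hydroxyphenyl on a carbon with a double bond to nitrogen, so the group on the carbon with a double bond to nitrogen is exchanged again, as it was from compound 1 to compound 2. That single measured step is the only one that bears on the new change, and it was within the scatter. For the measured compounds named here, no larger step is therefore expected here either: the estimated step for compound 3 is a number 3.2 percentage points lower from compound 2 to compound 3 (within the scatter), which is no change beyond the scatter. For compound 3 the expected value in this assay is 80%, with a range from 65% to 92%.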

Compound 3, a percentage reported as inhibition, at one concentration (the size of the read-out at that concentration, not a potency): 94.2%
The estimate for compound 3 lay 14.2 percentage points below the measured number, and the stated range ends below it.
By their numbers in this assay, from the lowest: compounds 2, 1 and 3 (each within the scatter of the next, the first and the last beyond it).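

In this assay, for the compounds shown here, the carbon with a double bond to nitrogen now shows that the exchanged group can matter: 4-(dimethylamino)phenyl in place of 2-hydroxyphenyl gives a number 11 percentage points higher from compound 2 to compound 3 (beyond the scatter), the first step beyond the scatter. The same entering group in place of 2-chlorophenyl gives a number 6.9 percentage points higher from compound 1 to compound 3 (within the scatter), so the size of the change at this position depends on the group that leaves as well as the group that enters. No measurement shown here offers an explanation for this difference.

The compounds shown do not separate the dimethylamino group from its place on the phenyl ring. A 4-hydroxyphenyl, a 2-(dimethylamino)phenyl or an unsubstituted phenyl on this carbon would help to separate the two, and the shared core stays unvaried throughout.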